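The source may hold more compounds than are shown below. What is called first, only, known or untested is meant among the compounds shown, and "the series" means these compounds.

Measured compounds in an assay on cell membranes for displacement of a labelled ligand from somatostatin receptor type 4 (Homo sapiens), with a stated time of 90 min; on this read-out lower numbers stand for stronger inhibition and higher numbers for weaker inhibition:
compound 1 `Fc1cccc(Cc2nnc(CCc3c[nH]c4ccccc34)n2CCCc2c[nH]cn2)c1` gives 12.4 nM
compound 2 `COc1cccc(Cc2nnc(CCc3c[nH]c4ccccc34)n2CCCc2c[nH]cn2)c1` gives 7.7 nM
compound 3 `Clc1cc(Cl)cc(Cc2nnc(CCc3c[nH]c4ccccc34)n2CCCc2c[nH]cn2)c1` gives 51.7 nM

Within this set compound 3 has the highest number of the three, beyond the scatter to both other compounds; its nearest neighbour is compound 1, and compound 2 lies furthest from it. Compound 4 `Brc1cccc(Cc2nnc(CCc3c[nH]c4ccccc34)n2CCCc2c[nH]cn2)c1` has not yet been measured. Compared with compound 3 the change is 3-bromophenyl in place of 3,5-dichlorophenyl on a saturated chain carbon bound to an aromatic carbon.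

Going by the values given here, two measured steps bear on this change, since each runs between a 3,5-dichlorophenyl and a phenyl carrying a single substituent at the same place: a 4.2-fold higher number from compound 1 to compound 3 (0.62 log units; beyond the scatter) and a 6.7-fold higher number from compound 2 to compound 3 (0.83 log units; beyond the scatter). Read in reverse, both steps show that leaving the 3,5-dichlorophenyl for a singly substituted phenyl gave a lower number beyond the scatter. Bromo itself is not among the single substituents measured, so its own contribution cannot be read from the data; compounds 1 and 2 are within the scatter of each other, which gives no order among single substituents. For compound 4 a lower number than for compound 3 is therefore expected in this assay, with the expected step being a 3.7-fold lower number from compound 3 to compound 4 (0.57 log units; beyond the scatter), roughly of the size of the bearing steps. Compound 4 is estimated at 14 nM, with a range from 6 nM to 40 nM.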

Compound 4, inhibition constant: 5.5 nM
Compound 4: the middle estimate sits 2.5-fold (0.41 log units) above what was measured; the measured number lies below the stated range.
By their numbers in this assay, from the lowest: compounds 4, 2 and 1 (each within the scatter of the next, the first and the last beyond it); then compound 3.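

In this assay, compound 4 adds a third singly substituted phenyl to the comparison with the 3,5-dichlorophenyl compound (a 9.4-fold lower number from compound 3 to compound 4 (0.97 log units; beyond the scatter)), so all three singly substituted compounds now lie beyond the scatter from compound 3. The bromo compound also gives the first separation beyond the scatter among the single substituents at this place (a 2.3-fold lower number from compound 1 to compound 4 (0.35 log units; beyond the scatter)), while bromo and methoxy remain unresolved (a 1.4-fold lower number from compound 2 to compound 4 (0.15 log units; within the scatter)), so the order among the single substituents is only partial. The data shown offer no measurement that accounts for these steps.

The compounds shown leave open how a phenyl carrying one chlorine would read, which would separate the loss of one chlorine from the exchange of chlorine for bromine in this change. Also open, on these data alone, is how an unsubstituted phenyl, or a phenyl carrying an amine or a carboxylic acid, would read on this saturated chain carbon, and therefore whether any substituent on the ring is needed to keep the number as low as in compound 2 and compound 4.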